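Replacing a Urea with a Carbamate on the Shared Core

The compounds below may be only part of what the source reports. "The series", "measured", "known", "first", "only" and "open" are said of these compounds alone.

Compound 1 `O=C(CC1CCCCCC1)N1CCC(c2nc(-c3ccc4ccccc4n3)no2)CC1`: 840 nM
Compound 2 `COc1ccccc1N(C)C(=O)N1CCC(c2nc(-c3ccc4ccccc4n3)no2)CC1`: 3100 nM
Compound 3 `COc1ccccc1NC(=O)N1CCC(c2noc(-c3ccc4ccccc4n3)n2)CC1`: 2400 nM

Among the compounds with values here, in a functional assay on Shh Light II cells (Mus musculus) for inhibition, read by a luciferase reporter (a lower number here means a stronger inhibitor, a higher number a weaker inhibitor), compound 2 gives the highest of the three numbers; compound 3 lies within the scatter of it, and the one measured step, a 3.7-fold higher number from compound 1 to compound 2 (0.57 log units; beyond the scatter), is modest but beyond the scatter. Compound 4 `COc1ccccc1OC(=O)N1CCC(c2nc(-c3ccc4ccccc4n3)no2)CC1` is derived from compound 2 by 2-methoxyphenoxy in place of (2-methoxyphenyl)(methyl)amino on a carbonyl carbon. That measured step exchanges a quite different group at the same carbonyl carbon, so it bears only loosely on this change, and compound 3 differs from compound 2 in more than one place. Within the data shown here, with no step mirroring the change, no shift beyond the scatter is expected. Compound 4 is therefore estimated at 2500 nM, between 800 nM and 8000 nM, which means an expected step of a 1.2-fold lower number from compound 2 to compound 4 (0.09 log units; within the scatter).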

Compound 4, half-maximal inhibitory concentration: 250 nM
Compound 4: the middle estimate sits 10-fold (1.00 log units) above what was measured; measured number below the stated range.
By their numbers in this assay, from the lowest: compound 4; then compound 1; then compounds 3 and 2 (each within the scatter of the next).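

Within the data shown here, at this carbonyl carbon, the link to the methoxyphenyl ring matters far more than the earlier compounds suggested: in this assay, 2-methoxyphenoxy in place of (2-methoxyphenyl)(methyl)amino gives a 12-fold lower number from compound 2 to compound 4 (1.09 log units; beyond the scatter) as a large step. The same group also beats cycloheptylmethyl, with a 3.4-fold lower number from compound 1 to compound 4 (0.53 log units; beyond the scatter) as a modest step, so an aromatic group here need not cost activity. No available evidence accounts for the size of these steps.

From the compounds shown here alone, it remains open whether the methoxy group is needed in compound 4. A plain phenoxy or a cycloheptyloxy group at this carbonyl carbon would help to settle that.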